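A few compounds are considered here, and "the series" means these few. Any claim that something is new, unique, unknown or untested is made for them only; others in the source may bear on it.

Of the compounds shown here, three have been measured in a functional assay on MCF7 cells (Homo sapiens) for inhibition, with a stated time of 72 h; on this read-out lower numbers stand for stronger inhibition of growth and higher numbers for weaker inhibition of growth. Compound 1 `C[Si](C)(C)C#Cc1cc(-c2nc3cc(F)ccc3s2)ccc1N` gives 160 nM in this assay, compound 2 `C#Cc1cc(-c2nc3ccccc3s2)ccc1N` gives 49 nM, and compound 3 `C[Si](C)(C)C#Cc1cc(-c2nc3c(F)cccc3s2)ccc1N` gives 520 nM. Compound 3 thus shows the highest number of the three, meaning the weakest inhibition of growth; compound 1 stands nearest to it, and compound 2 furthest, both gaps being beyond the usual scatter.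

The step from compound 3 to compound 4 `C[Si](C)(C)C#Cc1cc(-c2nc3ccccc3s2)ccc1N` is a single change: hydrogen in place of fluoro on an aromatic carbon, on an aromatic carbon of a six-membered aromatic ring of carbon only, part of a fused or bridged system of two rings. Among the compounds with values here, no measured pair here shows exactly this change, so its size in this assay cannot be read off directly. Compound 4 shares its core with compound 1 and compound 2, and both of those give lower numbers than compound 3, which is the basis for the following expectation.

The step from compound 3 to compound 4 is expected to be a 3.5-fold lower number from compound 3 to compound 4 (0.54 log units; beyond the scatter), toward stronger inhibition of growth. Compound 4 is therefore estimated at 150 nM, with a range from 50 nM to 450 nM.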

Compound 4, concentration for 50% growth inhibition: 710 nM
The estimate for compound 4 lay 4.7-fold (0.68 log units) below the measured number; the whole stated range lies below it.
By their numbers in this assay, from the lowest: compound 2; then compound 1; then compounds 3 and 4 (each within the scatter of the next).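

In this assay, hydrogen in place of fluoro at this position leaves the number within the usual scatter (a 1.4-fold higher number from compound 3 to compound 4 (0.14 log units; within the scatter)). The same kind of swap does exceed the scatter when it starts from the other fluoro compound (a 4.4-fold higher number from compound 1 to compound 4 (0.65 log units; beyond the scatter)), so among these compounds this change has no single size. The largest step lies at the triple-bonded carbon, where a group of 4 heavy atoms (3 carbon, 1 silicon; no ring) stands in place of a hydrogen atom (a 14-fold higher number from compound 2 to compound 4 (1.16 log units; beyond the scatter)).

Nothing shown gives a reason for any of these steps. Still open, going by these compounds, is how a chlorine on this aromatic carbon, or an amine or a longer chain on the triple-bonded carbon, would read out in this assay on this shared core.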